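Replacing Cycloheptyl with Oxetan-3-yl in Compound 3

The source may hold more compounds than are shown below. What is called first, only, known or untested is meant among the compounds shown, and "the series" means these compounds.

Three measured compounds share one core and differ in the group on an aromatic nitrogen. In a functional assay on HT-29 cells (Homo sapiens) for inhibition, read by luminescence and CellTiter-Glo, with a stated time of 24 h (a lower number here means that less compound is needed, a higher number that more compound is needed for the effect), compound 1 `CC(C)n1nc(C(=O)N[C@H]2COc3ccccc3N(C)C2=S)nc1Cc1ccccc1`, with isopropyl, gives 360 nM. Compound 2 `COCCn1nc(C(=O)N[C@H]2COc3ccccc3N(C)C2=S)nc1Cc1ccccc1`, with 2-methoxyethyl, gives 566 nM. Compound 3 `CN1C(=S)[C@@H](NC(=O)c2nc(Cc3ccccc3)n(C3CCCCCC3)n2)COc2ccccc21`, with cycloheptyl, gives 5530 nM, the highest number of the three.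

Compound 4 `CN1C(=S)[C@@H](NC(=O)c2nc(Cc3ccccc3)n(C3COC3)n2)COc2ccccc21` has not yet been measured. It carries oxetan-3-yl in place of cycloheptyl (oxetan-3-yl in place of cycloheptyl on an aromatic nitrogen).

Among the measured compounds shown here, no measured compound carries this group, so the closest guides are the steps at the same nitrogen. Going to cycloheptyl gives a 15-fold higher number from compound 1 to compound 3 (1.19 log units; beyond the scatter) and a 9.8-fold higher number from compound 2 to compound 3 (0.99 log units; beyond the scatter). By contrast, the step between the two smaller groups is a 1.6-fold higher number from compound 1 to compound 2 (0.20 log units; within the scatter), within the scatter. Oxetan-3-yl is also much smaller than cycloheptyl, so a step of similar size, in the opposite direction, is expected in this assay. The expected change is an 11-fold lower number from compound 3 to compound 4 (1.04 log units; beyond the scatter). For compound 4 the estimated value is 500 nM, with an expected range from 150 nM to 1800 nM.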

Compound 4, half-maximal effective concentration: 916 nM
For compound 4 the middle estimate is 1.8-fold (0.26 log units) below the measured one; measured number inside the range.
By their numbers in this assay, from the lowest: compounds 1, 2 and 4 (each within the scatter of the next, the first and the last beyond it); then compound 3.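

In this assay, a ring on this nitrogen does not by itself give a number like that of compound 3: oxetan-3-yl is also a ring, with fewer heavy atoms and one oxygen, and it gives a clearly lower number (a 6.0-fold lower number from compound 3 to compound 4 (0.78 log units; beyond the scatter)). Compound 4 falls within the scatter of the open-chain 2-methoxyethyl compound (a 1.6-fold higher number from compound 2 to compound 4 (0.21 log units; within the scatter)), but isopropyl still gives the lower number (a 2.5-fold higher number from compound 1 to compound 4 (0.41 log units; beyond the scatter)). No measured information here explains these differences.

A cyclobutyl or cyclopentyl group on this nitrogen would show whether the number rises gradually with ring size on the way to cycloheptyl, and cyclobutyl would also set oxetan-3-yl against an all-carbon ring of the same size. As far as these compounds go, how an amine on this nitrogen would behave also stays open.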